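From 2-methoxyphenyl to 2-ethylphenyl on the shared core

The compounds below may be only part of what the source reports. "The series", "measured", "known", "first", "only" and "open" are said of these compounds alone.

In an ADME assay (liver) for metabolic stability, with Liver microsome (Canis lupus familiaris) as the target, read by LC-MS, using microsomes, with a stated time of 30 min, tested at 4 uM (on this read-out higher numbers stand for a more stable compound and lower numbers for a less stable compound), three compounds have readings so far. Compound 1 (`Cc1nc(N2CCN(C)CC2)c2nc(-c3ccccc3Cl)n(CCO)c2n1`) gives 99% and stands well clear of the other two, a gap beyond the scatter. Compound 2 (`COCCn1c(-c2ccccc2Cl)nc2c(N3CCN4C(=O)CCC4C3)nc(C)nc21`) gives 35% in the same measurement. Compound 3 (`COc1ccccc1-c1nc2c(N3CCN(C)CC3)nc(C)nc2n1C1CCOCC1`) gives 36% and so sits level with compound 2 within the scatter, far from compound 1.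

Compound 4 (`CCc1ccccc1-c1nc2c(N3CCN(C)CC3)nc(C)nc2n1C1CCOCC1`) has not been measured. It differs from compound 3 in one place only (ethyl in place of methoxy on an aromatic carbon), with ethyl in place of methoxy on an aromatic carbon of a six-membered aromatic ring of carbon only, ortho to a large group.

Among the compounds with values here, no measured pair differs in one place, so the data do not show what this exchange does in this assay and any expectation is anchored on compound 3 alone. The estimated step (a number 3 percentage points lower from compound 3 to compound 4 (within the scatter)) is expected to stay within the scatter, with no direction favoured. The range is kept wide, since three readings give little guidance. For compound 4 the estimated value is 33% with an expected range from 15% to 55% in this assay.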

Compound 4, percent of the compound remaining: 74%
For compound 4 the middle estimate is 41 percentage points below the measured one; measured number outside the range, above it.
By their numbers in this assay, from the lowest: compounds 2 and 3 (each within the scatter of the next); then compound 4; then compound 1.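

In this assay, within the data shown here, the step of a number 38 percentage points higher from compound 3 to compound 4 (beyond the scatter) is the first comparison between compounds that differ in one place, and it shows that the group on an aromatic carbon, ortho to a large group, can alone move this read-out beyond the scatter. The exchange keeps the heavy-atom count of the group at 2 but replaces the carbon and oxygen of methoxy with the 2 carbons of ethyl, and the hydrogen-bond acceptor count of the group falls from 1 to 0, so a small change in the group goes with a large change in the percent of compound remaining. Nothing available explains why this exchange has so large an effect.

Going by these compounds, it remains open whether the step follows from the loss of the oxygen or from the ethyl group itself, and whether a propyl chain, a trifluoromethyl group or a carboxylic acid at the same place would give a similar reading. On these data alone, it is also open whether the exchange would have a similar effect with different groups elsewhere on the shared core, since this single step rests on one pair.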